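Methoxy for methyl on the chalcone aryl ring

The source may hold more compounds than are shown below. What is called first, only, known or untested is meant among the compounds shown, and "the series" means these compounds.

Measured compounds:
Compound 1, `O=C(/C=C/c1cccc(OCc2ccccc2)c1)c1ccc(O)cc1`, gives 2900 nM in a functional assay on MDA-MB-231 cells (Homo sapiens) for cytotoxicity, read by MTT assay, with a stated time of 68 h; a higher number here means a weaker inhibitor, a lower number a stronger inhibitor.
Compound 2, `Cc1ccc(C(=O)/C=C/c2cccc(OCc3ccccc3)c2)cc1`, gives 15600 nM in this assay.

Compound 2 stands highest of the two numbers in this assay, its nearest neighbour being compound 1 at a step of a 5.4-fold higher number from compound 1 to compound 2 (0.73 log units; beyond the scatter), a step that lies beyond the scatter and is described as modest.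

Compound 3, `COc1ccc(C(=O)/C=C/c2cccc(OCc3ccccc3)c2)cc1`, is not yet measured. It differs from compound 2 in one place: methoxy in place of methyl on an aromatic carbon. Going by the values given here, the one measured step that bears on this change is the exchange of hydroxy for methyl, where the number rose by a 5.4-fold higher number from compound 1 to compound 2 (0.73 log units; beyond the scatter). Methoxy brings one hydrogen-bond acceptor where methyl brings none, yet it lacks the donor of hydroxy, so the effect of this further exchange has no direct precedent here and any expectation rests on compound 1 and compound 2 alone.

Compound 3 is therefore expected to give 8000 nM in this assay, within a range of 3000 nM to 22000 nM. This estimate means a step of a 2.0-fold lower number from compound 2 to compound 3 (0.29 log units; within the scatter), a lowering expected to be near the edge of the scatter rather than clearly beyond it.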

Compound 3, half-maximal inhibitory concentration: 12400 nM
Estimate against measurement, compound 3: 1.6-fold (0.19 log units) below; the measured number falls inside the stated range.
By their numbers in this assay, from the lowest: compound 1; then compounds 3 and 2 (each within the scatter of the next).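

In this assay the exchange of methyl for methoxy, para to a large group, gives a 1.3-fold lower number from compound 2 to compound 3 (0.10 log units; within the scatter) and leaves compound 2 and compound 3 indistinguishable, even though methoxy brings a hydrogen-bond acceptor that methyl does not. Placing a methyl on the oxygen of compound 1 gives a 4.3-fold higher number from compound 1 to compound 3 (0.63 log units; beyond the scatter) and shows that an oxygen on the ring at this place is not enough on its own: the hydroxy of compound 1 is what sets it apart, and the methoxy of compound 3 does not share that standing. Compound 1 therefore has the lowest number of the three, while the 4-methylphenyl and 4-methoxyphenyl compounds sit together as a pair within the scatter of each other.

Going by these compounds, it remains open whether an amine or a carboxylic acid at this place would stand with compound 1 or with the other two, and whether the same order would hold on a different core. Nothing shown gives a measured reason for the way hydroxy stands apart from methyl and methoxy.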